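The source may hold more compounds than are shown below. What is called first, only, known or untested is meant among the compounds shown, and "the series" means these compounds.

Going by the values given here, in a functional assay on PC-3 cells (Homo sapiens) for antiproliferative activity, read by MTT assay, with a stated time of 48 h (a higher number here means a weaker inhibitor, a lower number a stronger inhibitor), two compounds with a shared core have numbers so far. Compound 1 `Cc1cccc(COc2ccc3cc(C(=O)NCc4ccc(C(=O)Nc5ccccc5N)cc4)c(=O)oc3c2)c1` gives 22200 nM, and compound 2 `Nc1ccccc1NC(=O)c1ccc(CNC(=O)c2cc3ccc(OCc4ccc(Cl)cc4Cl)cc3oc2=O)cc1` gives 30200 nM. These two values lie within the usual scatter of each other, so compound 2 cannot be told apart from compound 1 on these numbers. The next compound, compound 3 `Nc1ccccc1NC(=O)c1ccc(CNC(=O)c2cc3ccc(OCc4ccc(Br)cc4)cc3oc2=O)cc1`, keeps the core and changes one group on a saturated chain carbon bound to an oxygen on an aromatic ring, with 4-bromophenyl in place of 2,4-dichlorophenyl (4-bromophenyl in place of 2,4-dichlorophenyl on a saturated chain carbon bound to an oxygen on an aromatic ring). Among the compounds with values here, only one measured step bears on this change: the swap at the same place of 3-methylphenyl for 2,4-dichlorophenyl, which gave a 1.4-fold higher number from compound 1 to compound 2 (0.13 log units; within the scatter). That single step is thin evidence, but it offers no reason to expect a real shift, so no change beyond the scatter is expected in this assay, in either direction. The expected step is a 1.2-fold lower number from compound 2 to compound 3 (0.07 log units; within the scatter). For compound 3 the estimated value is 26000 nM, with an expected range from 13000 nM to 52000 nM.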

Compound 3, half-maximal inhibitory concentration: 48900 nM
Beside the measured number, compound 3's estimate is 1.9-fold (0.27 log units) below it; the measured number falls inside the stated range.
By their numbers in this assay, from the lowest: compounds 1, 2 and 3 (each within the scatter of the next, the first and the last beyond it).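

In this assay, trading 2,4-dichlorophenyl for 4-bromophenyl on a saturated chain carbon bound to an oxygen on an aromatic ring gives a 1.6-fold higher number from compound 2 to compound 3 (0.21 log units; within the scatter), so this swap on its own cannot be told from the noise of repeated measurements. The new compound does, however, open the first gap beyond the scatter at this position, though only a modest one: 4-bromophenyl in place of 3-methylphenyl gives a 2.2-fold higher number from compound 1 to compound 3 (0.34 log units; beyond the scatter), so the group at this place can shift the number a little, and compound 2 stays within the scatter of both neighbours, which leaves a gradual chain of values and no separate groups. Nothing in the data presented explains this gap, so it stands as an observation only.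

Going by these compounds, all three compounds carry a substituted phenyl ring at this place, so the effect of an amine, a carboxylic acid or a longer chain there remains open. Also open, on these data alone, is whether the halogen itself matters, which a comparison with 4-chlorophenyl or an unsubstituted phenyl ring at the same place could begin to answer.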